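Indole substituent change in a series at the assay limit

This account rests on a few compounds, and the source may have more. Where it says the series, first, only, none or still open, it means among the compounds named here.

Compound 2 `CO[C@@H]1[C@H](N(C)c2ncc(-c3c[nH]c4ccc(F)cc34)s2)C[C@H]2O[C@]1(C)n1c3ccccc3c3c4c(c5c6cc(Cl)ccc6n2c5c31)C(=O)NC4` carries a chloro group that compound 1 `CO[C@@H]1[C@H](N(C)c2ncc(-c3c[nH]c4ccc(F)cc34)s2)C[C@H]2O[C@]1(C)n1c3ccccc3c3c4c(c5c6ccccc6n2c5c31)C(=O)NC4` lacks. In a functional assay on K562 cells (Homo sapiens) for antiproliferative activity, read by CellTiter-Glo, with a stated time of 72 h (a higher number here means a weaker inhibitor, a lower number a stronger inhibitor), compound 1 gives > 10000 nM, which is a limit of the assay rather than a number. In this assay compound 2 gives > 10000 nM, likewise a limit. The step that the two limits leave unreadable from compound 1 to compound 2 therefore has no readable size. From the compounds shown here alone, compound 2 stands at the limit of > 10000 nM in this assay, at which 2 of the 2 values shown sit, so it is no stronger than that limit; where it lies beyond it is unknown.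

Compound 3 `COc1ccc2[nH]cc(-c3cnc(N(C)[C@@H]4C[C@H]5O[C@@](C)([C@@H]4OC)n4c6ccccc6c6c7c(c8c9cc(Cl)ccc9n5c8c64)C(=O)NC7)s3)c2c1` differs from compound 2 by methoxy in place of fluoro on an aromatic carbon, a methoxy in place of fluoro on an aromatic carbon of the 5-fluoro-1H-indol-3-yl group, giving 5-methoxy-1H-indol-3-yl. Going by the values given here, no measured step bears on this change; the only step in the pair, the chloro for hydrogen exchange, is itself unreadable. With both measured compounds at the limit, nothing sets a direction, and a change large enough to bring compound 3 inside the measurable range has no support here. The step that the limit leaves unreadable from compound 2 to compound 3 is therefore expected to be none beyond the scatter. Compound 3 is estimated at 15000 nM, within 5000 nM to 50000 nM, with a limit again the most likely report.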

Compound 3, half-maximal inhibitory concentration: > 10000 nM
Compound 3 ended at the assay's limit; the forecaster's own chance of this, stated with the estimate: 85%; the middle value lies beyond the limit too.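

Compound 3 gives > 10000 nM in this assay, a limit of the assay and not a number. No step can be read from compound 2 to compound 3, as both stand at a limit: the limit of > 10000 nM in this assay, at which 3 of the 3 values shown sit.

The compounds shown leave open how far beyond that limit each one lies, and whether 5-methoxy-1H-indol-3-yl differs from 5-fluoro-1H-indol-3-yl at all.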